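This account rests on a few compounds, and the source may have more. Where it says the series, first, only, none or still open, it means among the compounds named here.

Compounds measured in a functional assay on HepG2 cells (Homo sapiens) for antiproliferative activity, read by MTT assay, with a stated time of 24 h; a higher number here means a weaker inhibitor, a lower number a stronger inhibitor:

compound 1, `COC(=O)c1scc(-c2ccc(NC(=O)c3ccc4ccccc4c3)cc2)c1OC`, 19500 nM
compound 2, `COC(=O)c1scc(-c2ccc(NC(=O)c3ccc(F)c(Cl)n3)cc2)c1OC`, 10300 nM
compound 3, `COC(=O)c1scc(-c2ccc(NC(=O)c3cc(I)ccc3F)cc2)c1OC`, "not determined" (no result reported)

Within the data shown here, compound 1 and compound 2 share one core and differ only in the aryl group on the amide carbonyl; the single measured step, a 1.9-fold lower number from compound 1 to compound 2 (0.28 log units; within the scatter), lies within the scatter, so the two values show no real separation. Compound 3 stands without a number in this assay, so its own position among these values cannot be stated.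

Compound 4, `COC(=O)c1scc(-c2ccc(NC(=O)c3ccc(OC)nc3)cc2)c1OC`, differs from compound 3 in one place: 6-methoxypyridin-3-yl in place of 2-fluoro-5-iodophenyl on a carbonyl carbon. Among the measured compounds shown here, no measured step involves compound 3, so nothing bears directly on this change. For the measured compounds named here, the only step available, from compound 1 to compound 2, exchanged one aryl group on the same carbonyl for another and moved the number by a 1.9-fold lower number from compound 1 to compound 2 (0.28 log units; within the scatter), which is within the scatter. Since both measured values fall in the same region, compound 4 is expected to land in that region as well, with no step beyond the scatter foreseeable. Compound 4 is therefore estimated at 13000 nM, with a range from 4000 nM to 40000 nM.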

Compound 4, half-maximal inhibitory concentration: > 50000 nM
Compound 4: a limit, no number (the forecaster's own chance of this, stated with the estimate: 20%); middle value at least 3.8-fold (0.58 log units) from the limit.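

Compound 4 gives no number in this assay, only a limit: the limit of > 50000 nM in this assay, at which 1 of the 4 values shown sits. The exchange of 6-chloro-5-fluoropyridin-2-yl for 6-methoxypyridin-3-yl gives an at least 4.8-fold higher number from compound 2 to compound 4 (0.68 log units; beyond the scatter) and the exchange of naphthalen-2-yl for the same group gives an at least 2.5-fold higher number from compound 1 to compound 4 (0.40 log units; beyond the scatter) on the same carbonyl carbon. The earlier pair had offered only a step within the scatter, so the group on this carbonyl now proves able to move the number beyond the scatter, while compound 3 has no result and the step from it to compound 4 cannot be read.

From the compounds shown here alone, with a limit at one end, the full size of both steps stays open. Also open, going by these compounds, is whether the methoxy group itself goes with the higher number, and what an amine or a carboxylic acid in its place would give.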